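Chloro Added to a Phenyl Analogue Already at the Limit

This account rests on a few compounds, and the source may have more. Where it says the series, first, only, none or still open, it means among the compounds named here.

Measured compounds:
compound 1 `Cc1cc(S(=O)(=O)Nc2nc3cscc3c(=O)n2Cc2ccccc2)c(S)cc1Cl`: 16600 nM
compound 2 `Cc1cc(S(=O)(=O)Nc2nc3cc(-c4ccccc4)sc3c(=O)n2Cc2ccccc2)c(S)cc1Cl`: > 100000 nM

In a functional assay on SN12C cells (Homo sapiens) for inhibition (a lower number here means a stronger inhibitor of growth, a higher number a weaker inhibitor of growth), compound 1 gives 16600 nM. For compound 2 the result is not a number but a limit of the assay, > 100000 nM. Going by these compounds, compound 2 therefore stands at the limit of > 100000 nM in this assay, at which 1 of the 2 values shown sits, so its true value is unknown beyond the fact that it lies past the range the assay reports. For the measured compounds named here, the two values together show only that compound 1 inhibits growth measurably while compound 2 does not within the tested range.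

Compound 3 `Cc1cc(S(=O)(=O)Nc2nc3cc(-c4ccc(Cl)cc4)sc3c(=O)n2Cc2ccccc2)c(S)cc1Cl` is built from compound 2 by a single change: chloro in place of hydrogen on an aromatic carbon. Going by the values given here, no measured pair here shows what such a change does in this assay, so there is no step to lean on. With compound 2 already at the limit, the expected step from compound 2 to compound 3, a step that the limit leaves unreadable from compound 2 to compound 3, is none beyond the scatter, and the most likely outcome is again a limit rather than a number. Compound 3 is estimated at 150000 nM, with a range from 50000 nM to 500000 nM.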

Compound 3, concentration for 50% growth inhibition: > 100000 nM
Compound 3: a limit, no number (the forecaster's own chance of this, stated with the estimate: 75%); the middle value is on the limit's open side.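

For the compounds shown here, compound 2 and compound 3 both stand at a limit of the assay rather than at a number, so no step from phenyl to 4-chlorophenyl can be read between them, because of this shared limit: the limit of > 100000 nM in this assay, at which 2 of the 3 values shown sit.

The compounds shown leave open what chloro in place of hydrogen does to growth inhibition in this assay and how far past the limit compound 2 and compound 3 truly lie.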